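The compounds below may be only part of what the source reports. "The series", "measured", "known", "first", "only" and "open" are said of these compounds alone.

Working notes, series with the shared core of compound 1 `[N-]=[N+]=NCc1nnc(-c2cc(S(N)(=O)=O)c(SCc3ccccc3)cc2Cl)o1`. In a functional assay on HCT-116 cells (Homo sapiens) for cytotoxicity, read by MTT assay, with a stated time of 72 h (on this read-out lower numbers stand for stronger inhibition and higher numbers for weaker inhibition), compound 1 gives 100000 nM. Compound 2 `NC(=O)c1cn(Cc2nnc(-c3cc(S(N)(=O)=O)c(SCc4ccccc4)cc3Cl)o2)nn1` gives 72000 nM in this assay, and compound 3 `NCc1nnc(-c2cc(S(N)(=O)=O)c(SCc3ccccc3)cc2Cl)o1` gives 120000 nM. Compound 3 lies within the scatter of both others; the steps of a 1.2-fold higher number from compound 1 to compound 3 (0.08 log units; within the scatter) and a 1.7-fold higher number from compound 2 to compound 3 (0.22 log units; within the scatter) show that, as does a 1.4-fold lower number from compound 1 to compound 2 (0.14 log units; within the scatter) between the other two. All three changes sit on the saturated chain carbon bound to an aromatic carbon, the same place where compound 4 `NS(=O)(=O)c1cc(-c2nnc(CNC(=O)c3ccccc3)o2)c(Cl)cc1SCc1ccccc1` differs from compound 3: benzoyl in place of hydrogen on an amine nitrogen. Since none of those exchanges moved this assay beyond the scatter, no step beyond the scatter is expected for a 1.1-fold lower number from compound 3 to compound 4 (0.04 log units; within the scatter) either. Compound 4 is therefore estimated at 110000 nM, within 40000 nM to 300000 nM.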

Compound 4, half-maximal inhibitory concentration: 42000 nM
Estimate against measurement, compound 4: 2.6-fold (0.42 log units) above, within the range that was stated.
By their numbers in this assay, from the lowest: compounds 4, 2, 1 and 3 (each within the scatter of the next, the first and the last beyond it).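

Benzoyl in place of hydrogen on the amine nitrogen gives the first step beyond the scatter at this position (a 2.9-fold lower number from compound 3 to compound 4 (0.46 log units; beyond the scatter)), and benzamido in place of azido also lies beyond it (a 2.4-fold lower number from compound 1 to compound 4 (0.38 log units; beyond the scatter)). Benzamido in place of 4-carbamoyl-1H-1,2,3-triazol-1-yl stays within the scatter (a 1.7-fold lower number from compound 2 to compound 4 (0.23 log units; within the scatter)), so compound 4 is separated from only two of the other three compounds. No measured evidence bears on the cause of these steps.

From the compounds shown here alone, whether the step needs the aromatic ring or only the carbonyl stays open; an acetyl group on the same amine nitrogen would separate the two. Going by these compounds, the effect of a substituted benzoyl, such as 4-methoxybenzoyl, also remains open.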